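The compounds below may be only part of what the source reports. "The series", "measured", "known", "first", "only" and "open" are said of these compounds alone.

Measured so far in a functional assay on Caco-2 cells (Homo sapiens) for cytotoxicity, read by colony formation; a lower number here means a stronger inhibitor, a higher number a weaker inhibitor:
- compound 1 `COC(=O)C1=CO[C@@H](O[C@@H]2O[C@H](COC(c3ccccc3)(c3ccccc3)c3ccccc3)[C@@H](O)[C@H](O)[C@H]2O)[C@@H]2[C@@H](C)[C@@H](O)C[C@H]12`: 2.54 ug/mL
- compound 2 `COC(=O)C1=CO[C@@H](O[C@@H]2O[C@H](COC(c3ccccc3)(c3ccccc3)c3ccccc3)[C@@H](OC(=O)O)[C@H](OC(C)=O)[C@H]2OC(C)=O)[C@@H]2[C@@H](C)[C@@H](OC(C)=O)C[C@H]12`: 1.28 ug/mL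
- compound 3 `CCCCCCCCCCCC(=O)OC[C@H]1O[C@@H](O[C@@H]2OC=C(C(=O)OC)[C@H]3C[C@H](OC(C)=O)[C@H](C)[C@@H]23)[C@H](OC(C)=O)[C@@H](OC(C)=O)[C@@H]1OC(C)=O`: 1.24 ug/mL

Compound 3, at 1.24 ug/mL, lies within the usual scatter of compound 2, at 1.28 ug/mL, so these two cannot be told apart. Compound 1, at 2.54 ug/mL, has a higher number than compound 3, and that gap lies just beyond the scatter.

The next compound to test is compound 4 `COC(=O)C1=CO[C@@H](O[C@@H]2O[C@H](COC(=O)c3cccc([N+](=O)[O-])c3)[C@@H](OC(C)=O)[C@H](OC(C)=O)[C@H]2OC(C)=O)[C@@H]2[C@@H](C)[C@@H](OC(C)=O)C[C@H]12`. It differs from compound 3 by 3-nitrophenyl in place of undecyl on a carbonyl carbon, which puts 3-nitrophenyl in place of undecyl on a carbonyl carbon. Within the data shown here, no two measured compounds differ in only one place, so the data show no direct precedent for this swap. Compound 2, which has aromatic rings and no undecyl, gives 1.28 ug/mL, within the scatter of compound 3. A change of no size beyond the scatter in this assay is therefore expected. The estimated move is a 1.3-fold higher number from compound 3 to compound 4 (0.11 log units; within the scatter), slightly towards a higher number. For compound 4 the expected value is 1.6 ug/mL, with an estimated range from 0.7 ug/mL to 3.6 ug/mL.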

Compound 4, half-maximal inhibitory concentration: 5.42 ug/mL
The estimate for compound 4 lay 3.4-fold (0.53 log units) below the measured number, outside the stated range (above it).
By their numbers in this assay, from the lowest: compounds 3, 2 and 1 (each within the scatter of the next, the first and the last beyond it); then compound 4.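

Among these compounds, this is the first pair here that differs in one place, so it gives the first direct reading of this position. In this assay putting 3-nitrophenyl in place of undecyl on a carbonyl carbon gives a 4.4-fold higher number from compound 3 to compound 4 (0.64 log units; beyond the scatter) and so makes the inhibitor weaker, which shows that the group held on this carbonyl carbon matters to the result. The compounds shown contain no measurement that explains the shift.

This one pair cannot separate the part played by the aromatic ring from that of the nitro group, or from the loss of the undecyl chain itself. A plain phenyl group, a ring bearing an amine in place of the nitro group, or a shorter chain at the same place would each help to pull these apart.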